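Replacing a Methoxyphenyl Group with a Pyridinylmethyl Group

This account rests on a few compounds, and the source may have more. Where it says the series, first, only, none or still open, it means among the compounds named here.

Of the compounds shown here, three built on one shared core have been measured in a functional assay on A-375 cells (Homo sapiens) for antiproliferative activity, read by CCK-8 assay, with a stated time of 72 h, tested at 2 uM; on this read-out higher numbers stand for a stronger effect at the one concentration tested and lower numbers for a weaker effect. Compound 1 `Nc1ccccc1NC(=O)c1ccc(CSC(=S)N2CCN(C(c3ccccc3)c3ccccc3)CC2)cc1` gives 8.7%. Compound 2 `Nc1ccccc1NC(=O)c1ccc(CSC(=S)N2CCN(c3ccccc3)CC2)cc1` gives 27.5%, and compound 3 `COc1ccc(N2CCN(C(=S)SCc3ccc(C(=O)Nc4ccccc4N)cc3)CC2)cc1` gives 28.1%, the highest of the three numbers, though compound 2 lies within the scatter of it and only compound 1 lies beyond it. Within the data shown here, the one single-point step among them, a number 0.6 percentage points higher from compound 2 to compound 3 (within the scatter), is within the scatter.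

Compound 4 `Nc1ccccc1NC(=O)c1ccc(CSC(=S)N2CCN(Cc3ccncc3)CC2)cc1` differs from compound 3 by (pyridin-4-yl)methyl in place of 4-methoxyphenyl on an amine nitrogen in a ring. Among the measured compounds shown here, no measured step follows the same kind of change: the step from compound 2 to compound 3 concerns only the methoxy group, and no measured pair exchanges an aromatic ring bound directly to the amine nitrogen for one joined through a methylene. For the measured compounds named here, the values of compound 1 and compound 3 show only that compound 1 sits well below both compound 3 and compound 2. The author therefore expects for compound 4 a step of a number 8.1 percentage points lower from compound 3 to compound 4 (within the scatter), downward but of uncertain size. Compound 4 is estimated at 20%, within a range from 5% to 38%.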

Compound 4, a percentage reported as inhibition, at one concentration (the size of the read-out at that concentration, not a potency): 33.1%
Compound 4: the middle estimate sits 13.1 percentage points below what was measured; measured number inside the range.
By their numbers in this assay, from the lowest: compound 1; then compounds 2, 3 and 4 (each within the scatter of the next).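

In this assay the exchange of 4-methoxyphenyl for (pyridin-4-yl)methyl on the amine nitrogen in the ring gives a number 5 percentage points higher from compound 3 to compound 4 (within the scatter) and the exchange of phenyl for the same group gives a number 5.6 percentage points higher from compound 2 to compound 4 (within the scatter). The earlier compounds had shown this position only with rings bound directly to the nitrogen among the single-place steps, whereas these two steps show that a ring joined through a methylene, and carrying a ring nitrogen, gives a number that cannot be separated from theirs at the one concentration tested. Nothing available offers a reason for this result. The compounds shown leave open whether a plain benzyl group on this nitrogen would read the same as (pyridin-4-yl)methyl. They also leave open whether a longer chain, such as 2-phenylethyl, would carry the number beyond the scatter.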